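A few compounds are considered here, and "the series" means these few. Any claim that something is new, unique, unknown or untested is made for them only; others in the source may bear on it.

Compound 3 `CC(c1ccccc1)n1cnnc1-c1cccc(Cl)c1Cl` stands second highest of the three numbers in a functional assay for antagonist activity at P2X purinoceptor 7 (Homo sapiens); a higher number here means a weaker inhibitor, a lower number a stronger inhibitor: compound 3 gives 1050 nM. Compound 2 `FC(F)(F)c1cccc(Cn2cnnc2-c2cccc(Cl)c2Cl)c1` gives 1290 nM, within the scatter of compound 3. Compound 1 `COc1cccc(Cn2cnnc2-c2cccc(Cl)c2Cl)c1` gives 214 nM, a gap from compound 3 that lies beyond the scatter. Among the compounds with values here, the one step measured so far, a 6.0-fold higher number from compound 1 to compound 2 (0.78 log units; beyond the scatter), alters a group on an aromatic carbon and leaves the chain carbon untouched. Compound 4 `CC(C)(c1ccccc1)n1cnnc1-c1cccc(Cl)c1Cl` differs from compound 3 by methyl in place of hydrogen on a saturated chain carbon bound to an aromatic carbon, an aromatic nitrogen and a saturated chain carbon. Within the data shown here, no measured step bears on this change, so no step beyond the scatter is expected in this assay . The number for compound 4 is therefore estimated at 1000 nM, within 400 nM to 3000 nM. The expected step is a 1.1-fold lower number from compound 3 to compound 4 (0.02 log units; within the scatter).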

Compound 4, half-maximal inhibitory concentration: 13200 nM
For compound 4 the middle estimate is 13-fold (1.12 log units) below the measured one; measured number above the stated range.
By their numbers in this assay, from the lowest: compound 1; then compounds 3 and 2 (each within the scatter of the next); then compound 4.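

In this assay, methyl in place of hydrogen on the saturated chain carbon gives a 13-fold higher number from compound 3 to compound 4 (1.10 log units; beyond the scatter). Within the data shown here, this is the first measured step at this carbon, and it shows that the chain carbon, not only the aromatic carbon changed between compound 1 and compound 2, can move the number beyond the scatter. Nothing available accounts for the step.

On these data alone, whether a hydroxyl or an amine in place of the added methyl would give a step of similar size remains open. So does whether a methoxy on an aromatic carbon of compound 4 would change its number.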